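The source may hold more compounds than are shown below. What is called first, only, known or untested is meant among the compounds shown, and "the series" means these compounds.

Measured compounds:

Compound 1, `Cc1cc2c(cc1Cc1ccc(-n3ccnc3)cc1)C(=O)N([C@H]1CCOC[C@@H]1O)C2`: in an ADME assay on microsomes from liver (Homo sapiens) for metabolic stability (a lower number here means slower removal, a higher number faster removal of the compound), compound 1 gives < 8 mL/min/kg, a limit of the assay rather than a number.
Compound 2, `Cc1cn(-c2ccc(Cc3cc4c(cc3C)CN([C@H]3CCOC[C@@H]3O)C4=O)cc2)cn1`: in this assay compound 2 gives 30 mL/min/kg.
Compound 3, `Cc1nc(-c2ccc(Cc3cc4c(cc3C)CCN([C@H]3CCOC[C@@H]3O)C4=O)cc2)co1`: in this assay compound 3 gives 21 mL/min/kg.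

Compound 1 and compound 2 differ in one place, (hydrogen in place of methyl on an aromatic carbon), and this change brings an at least 3.7-fold lower number from compound 2 to compound 1 (0.57 log units; beyond the scatter). The size of that step is bounded only on one side, since compound 1 sits at the limit of < 8 mL/min/kg in this assay, at which 1 of the 3 values shown sits.

Compound 4, `Cc1cc2c(cc1Cc1ccc(-c3cocn3)cc1)C(=O)N([C@H]1CCOC[C@@H]1O)CC2`, is not yet measured. It stands to compound 3 as compound 1 stands to compound 2: hydrogen in place of methyl on an aromatic carbon. The place is not identical, however: in the measured pair the ring is a five-membered aromatic ring with 2 nitrogen, two ring bonds from the ring nitrogen, whereas here it is a ring with 1 nitrogen and 1 oxygen, next to the ring oxygen, so it is the same kind of change rather than the same one. How the core of compound 3 differs from that of compound 2 is not broken down here.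

The step from compound 3 to compound 4 is expected to be a 2.1-fold lower number from compound 3 to compound 4 (0.32 log units; beyond the scatter) in this assay, resting on the measured pair, where compound 2 to compound 1 gave an at least 3.7-fold lower number from compound 2 to compound 1 (0.57 log units; beyond the scatter). Compound 4 is therefore estimated at 10 mL/min/kg, with a likely range from 5 mL/min/kg to 20 mL/min/kg.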

Compound 4, clearance: 13 mL/min/kg
Beside the measured number, compound 4's estimate is 1.3-fold (0.11 log units) below it; the measured number falls inside the stated range.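

In this assay, the change from 2-methyl-1,3-oxazol-4-yl to 1,3-oxazol-4-yl gives a 1.6-fold lower number from compound 3 to compound 4 (0.21 log units; within the scatter), so on this core the step cannot be told apart from repeat measurement. Set beside the step on the other core, this result shows no firm size for the change that can be carried from one core to another, and it does not show that the core alters that size either: the same change on two cores in this assay, an at least 3.7-fold lower number (0.57 log units; beyond the scatter) from compound 2 to compound 1 and a 1.6-fold lower number (0.21 log units; within the scatter) from compound 3 to compound 4; the limit leaves it open whether they differ. The value of compound 1 is a limit of the assay and not a number, so the earlier step has no upper end: the limit of < 8 mL/min/kg in this assay, at which 1 of the 4 values shown sits.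

The compounds shown leave open how an ethyl group, a methoxy group or a chlorine atom in place of the methyl would read in this assay. They also leave open whether the five-membered aromatic ring with 1 nitrogen and 1 oxygen and the one with 2 nitrogen would read alike if each were carried on the same core.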